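A few compounds are considered here, and "the series" means these few. Any claim that something is new, unique, unknown or untested is made for them only; others in the source may bear on it.

Measured so far in a functional assay (thoracic aorta) for inhibition, with Rattus norvegicus as the target; a lower number here means a stronger inhibitor, a higher number a weaker inhibitor:

Compound 1 `Cc1cccc(S(=O)(=O)N[C@H]2C3CC[C@H](C3)[C@@H]2C/C=C\CCCC(=O)O)c1` gives 3.2 nM.
Compound 2 `CCCCCCS(=O)(=O)N[C@H]1C2CC[C@H](C2)[C@@H]1C/C=C\CCCC(=O)O` gives 17.2 nM.

Going by the values given here, compound 2 has the higher of the two numbers, so it is the weaker inhibitor of the pair; its only neighbour is compound 1, reached by a 5.4-fold higher number from compound 1 to compound 2 (0.73 log units; beyond the scatter). The two share the same core; they differ only in the group on the sulfonyl sulfur.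

Compound 3 `Cc1ccccc1S(=O)(=O)N[C@H]1C2CC[C@H](C2)[C@@H]1C/C=C\CCCC(=O)O` is not yet measured. Compared with compound 2 the change is 2-methylphenyl in place of hexyl on a sulfonyl sulfur. Compound 3 thus carries a methylphenyl on the sulfonyl sulfur like compound 1, though the 2-methylphenyl rather than the 3-methylphenyl.

Among the compounds with values here, only one measured step bears on this: the move from an aryl to hexyl on that sulfur, a 5.4-fold higher number from compound 1 to compound 2 (0.73 log units; beyond the scatter), a modest loss. Compound 3 reverses that move, so a gain of about the same size is expected, back toward the number of compound 1, with some allowance since the methyl now sits in a different isomer, for which no measurement exists. Compound 3 is therefore expected to give about 5 nM, in the range 1.5 nM to 16 nM. That expectation corresponds to a step of a 3.4-fold lower number from compound 2 to compound 3 (0.54 log units; beyond the scatter).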

Compound 3, half-maximal inhibitory concentration: 3.7 nM
Compound 3: the middle estimate sits 1.4-fold (0.13 log units) above what was measured, and the stated range covers the measured number.
By their numbers in this assay, from the lowest: compounds 1 and 3 (each within the scatter of the next); then compound 2.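

In this assay, replacing hexyl with 2-methylphenyl on the sulfonyl sulfur gives a 4.6-fold lower number from compound 2 to compound 3 (0.67 log units; beyond the scatter) and so lands on the low-number side of hexyl, as the 3-methylphenyl of compound 1 does. The gap between hexyl and an aromatic ring at this position therefore no longer rests on a single aryl group, since two different methylphenyl groups now stand against the one chain. Moving the methyl from one isomer to the other gives a 1.2-fold higher number from compound 1 to compound 3 (0.06 log units; within the scatter), so this assay cannot tell compound 1 and compound 3 apart, and the exact place of the methyl shows no measurable effect in this pair, while nothing shown explains the difference between the aryl groups and hexyl.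

Still open, from the compounds shown here alone, is whether the methyl is needed at all, which a plain phenyl ring on the sulfonyl sulfur would test, and whether a larger or differently substituted ring, such as a chlorophenyl or a naphthyl, would keep the low numbers. Hexyl is also the only chain here, so a shorter chain such as butyl could show whether chain length matters.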